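The source may hold more compounds than are shown below. What is called first, only, known or untested is meant among the compounds shown, and "the series" means these compounds.

Of the compounds shown here, three have so far been measured in an assay on isolated protein for inhibition of Amine oxidase [flavin-containing] B (Homo sapiens); on this read-out lower numbers stand for stronger inhibition and higher numbers for weaker inhibition. Compound 1 `C#CCNC1CCc2c(SCCc3cccc(C)c3)cccc21` gives 0.35 nM. For the measured compounds named here, compound 3 `C#CCNC1CCc2c(SCCc3cccc(OC)c3)cccc21` differs from compound 1 only by methoxy in place of methyl on an aromatic carbon, and in this assay compound 3 gives 28700 nM, so that the single change produced an 82000-fold higher number from compound 1 to compound 3 (4.91 log units; beyond the scatter). Compound 2 `C#CCNC1CCc2c(SCc3ccc(C)cc3)cccc21` gives 1560 nM in this assay; its number lies between those of compound 1 and compound 3. The difference between the core of compound 2 and the core of compound 1 is not broken down here.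

Compound 4 `C#CCNC1CCc2c(SCc3ccc(OC)cc3)cccc21` is not yet measured. It differs from compound 2 by methoxy in place of methyl on an aromatic carbon. This is the same kind of change as that from compound 1 to compound 3, but not the same: in compound 3 the methoxy sits meta to a large group, whereas in compound 4 it sits para to a large group, and the cores of compound 2 and compound 1 differ in a way not broken down here. Going by the values given here, the only measured instance of the change, from compound 1 to compound 3, was very large, and on that basis a weakening is expected for compound 4 as well. Because compound 2 already starts from 1560 nM, the expected step is taken to be smaller than the measured one, namely a 19-fold higher number from compound 2 to compound 4 (1.28 log units; beyond the scatter). Compound 4 is therefore estimated at 30000 nM in this assay, most likely between 5000 nM and 200000 nM, with a real possibility that only a limit is reported.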

Compound 4, half-maximal inhibitory concentration: 1900 nM
Beside the measured number, compound 4's estimate is 16-fold (1.20 log units) above it; the measured number lies below the stated range.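

In this assay, methoxy in place of methyl on an aromatic carbon gives a 1.2-fold higher number from compound 2 to compound 4 (0.09 log units; within the scatter), so on the core of compound 2 this change leaves the number within the scatter. Set beside the earlier instance of the same change, the outcome on one core clearly does not predict the outcome on the other in this series: the same change on two cores in this assay, an 82000-fold higher number (4.91 log units; beyond the scatter) from compound 1 to compound 3 and a 1.2-fold higher number (0.09 log units; within the scatter) from compound 2 to compound 4, 67000-fold (4.83 log units) apart, beyond the scatter of two such steps

What this does not show is which structural difference accounts for the gap, since the two pairs differ both in their cores and in where the group sits on the aromatic ring, with the methoxy of compound 4 para to a large group, and these two differences are not separated by the compounds shown; each core also offers only a single instance of the change, so neither step can be taken as typical of its core.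

The compounds shown leave open how methoxy and methyl would compare on each core if both cores carried the group in the same place. They also leave open whether other groups in that place, such as chlorine, hydroxyl or trifluoromethyl, would split between the two cores in the same way.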